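Replacing methyl with thiophen-2-yl in a small series

The source may hold more compounds than are shown below. What is called first, only, known or untested is meant among the compounds shown, and "the series" means these compounds.

In a functional assay on RS4-11 cells (Homo sapiens) for inhibition, read by CCK-8 assay, with a stated time of 48 h, tested at 20 uM (on this read-out lower numbers stand for less inhibition of growth and higher numbers for more inhibition of growth at the one concentration tested), compound 1 `Cc1nnc(NC(=O)/C(C#N)=C/c2cccc(OS(C)(=O)=O)c2)s1` gives 33% and compound 2 `Cc1ccc(S(=O)(=O)Oc2cccc(/C=C(\C#N)C(=O)Nc3nnc(C)s3)c2)cc1` gives 28%. Among the measured compounds shown here, these two numbers lie within the usual scatter of each other, so compound 2 stands level with the only other compound measured. Compound 3 `Cc1ccc(S(=O)(=O)Oc2cccc(/C=C(\C#N)C(=O)Nc3nnc(-c4cccs4)s3)c2)cc1` differs from compound 2 in one place: thiophen-2-yl in place of methyl on an aromatic carbon. Thiophen-2-yl stands in place of methyl on an aromatic carbon, turning 5-methyl-1,3,4-thiadiazol-2-yl into 5-(thiophen-2-yl)-1,3,4-thiadiazol-2-yl. For the measured compounds named here, the one measured step, a number 5 percentage points lower from compound 1 to compound 2 (within the scatter), put 4-methylphenyl in place of methyl on a sulfonyl sulfur. Going by the values given here, that is a different place, so it bears only weakly on this change, and no measured step tests it directly. In this assay, no shift beyond the scatter is therefore expected, though the uncertainty is wide. The expected change is a number 4 percentage points higher from compound 2 to compound 3 (within the scatter). For compound 3 the estimate is 32%, with an expected range of 15% to 52%.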

Compound 3, percent growth inhibition at one concentration: 25%
Estimate against measurement, compound 3: 7 percentage points above; the measured number falls inside the stated range.
By their numbers in this assay, from the lowest: compounds 3, 2 and 1 (each within the scatter of the next).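

In this assay, the change at this position gives a number 3 percentage points lower from compound 2 to compound 3 (within the scatter). Among the compounds shown here, this is the first measured step at this place, and it shows that the read-out does not separate methyl from the much larger thiophen-2-yl, which brings a whole five-membered aromatic ring and a sulfur atom onto the same aromatic carbon. Nothing shown here gives a reason why growth inhibition stays level across this change.

The compounds shown leave open whether a different kind of group on this carbon, such as an amine, a carboxylic acid or a longer chain, would shift the number beyond the scatter. They also leave open whether thiophen-2-yl would behave the same way with methyl rather than 4-methylphenyl on the sulfonyl sulfur.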